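Working notes on the step from compound 1 to compound 4

The source may report more compounds than this note shows. Statements on the series, on what has been measured and on what is new or still open speak of the compounds shown alone.

All values come from a functional assay on MCF7 cells (Homo sapiens) for inhibition, read by MTT assay; on this read-out higher numbers stand for weaker inhibition and lower numbers for stronger inhibition. Compound 1 `CCCCCCCCn1cc(/C=C/C(=O)c2ccc(N)cc2)nn1` gives 31000 nM. Compound 3 `CC(C)(C)OC(=O)N1CCN(CC(=O)Nc2ccc(C(=O)/C=C/c3cn(Cc4ccc(Br)cc4)nn3)cc2)CC1` gives 31000 nM, so compound 1 stands level with compound 3 at the digits shown, a gap within the scatter from which no order can be read. Compound 2 `CCCCCCCCCCn1cc(/C=C/C(=O)c2ccc(NC(=O)CN3CCN(c4ccccc4)CC3)cc2)nn1` gives only a limit of the assay, > 100000 nM, and not a number. That limit is the limit of > 100000 nM in this assay, at which 1 of the 3 values shown sits.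

Compound 4 `CCCCCCCCn1cc(/C=C/C(=O)c2ccc(NC(=O)CBr)cc2)nn1` has not yet been measured in this assay. It differs from compound 1 by (bromomethyl)carbonyl in place of hydrogen on a nitrogen on an aromatic ring. Among the measured compounds shown here, no pair of measured compounds isolates that change: compound 3 differs from compound 1 in more than one place, and its value next to that of compound 1 shows only that the two sit at the same level. For the step from compound 1 to compound 4 the expectation is a moderate move toward stronger inhibition, somewhat beyond the scatter, a 3.1-fold lower number from compound 1 to compound 4 (0.49 log units; beyond the scatter). Compound 4 is accordingly estimated at 10000 nM, with a range from 2000 nM to 50000 nM, the estimate resting on compound 1 at 31000 nM as the starting point.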

Compound 4, half-maximal inhibitory concentration: 12900 nM
The estimate for compound 4 lay 1.3-fold (0.11 log units) below the measured number; the range from low to high includes it.
By their numbers in this assay, from the lowest: compound 4; then compounds 1 and 3 (each within the scatter of the next). At a limit, above all of these: compound 2.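

In this assay the series now holds its first step that isolates a single change: a 2.4-fold lower number from compound 1 to compound 4 (0.38 log units; beyond the scatter). With the rest of compound 1 held fixed, going from amino to ((bromomethyl)carbonyl)amino moves the number toward stronger inhibition, so this nitrogen is a position where a change registers in this assay, though the step is modest in size. Compound 2 and compound 3 also carry a carbonyl-bearing group on that nitrogen, but each differs from compound 1 in more than one place, so neither could show what this substitution alone does.

No measurement shown bears on why the number moves with this change. Open, from the compounds shown here alone, is whether the step depends on the bromine or on the carbonyl alone, a question that an acetyl group on the same nitrogen or a chloroacetyl group in place of the (bromomethyl)carbonyl would address, and whether the step holds with a longer chain on the triazole nitrogen in place of the chain in compound 4.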